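A few compounds are considered here, and "the series" means these few. Any claim that something is new, unique, unknown or untested is made for them only; others in the source may bear on it.

Measured so far:
compound 1 `O=C(/C=C\c1ccc(O)cc1)N1N=C(c2ccncc2)OC1c1c[nH]c2ccccc12` — > 30 ug/mL
compound 2 `O=C(/C=C\c1ccc(Cl)cc1Cl)N1N=C(c2ccncc2)OC1c1c[nH]c2ccccc12` — 29.3 ug/mL

In an ADME assay on HeLa cells (Homo sapiens) for cytotoxicity, read by MTT assay, with a stated time of 72 h (on this read-out higher numbers stand for weaker inhibition of growth and lower numbers for stronger inhibition of growth), compound 1 gives > 30 ug/mL, which is a limit of the assay and not a number. Compound 2 gives 29.3 ug/mL in this assay. The one measured step, an at least 1.0-fold lower number from compound 1 to compound 2 (0.01 log units; that floor lies within the scatter), is read against (the limit of > 30 ug/mL in this assay, at which 1 of the 2 values shown sits), so nothing beyond the scatter is shown for swapping the 4-hydroxyphenyl for a halogenated phenyl at this place.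

Compound 3 `O=C(/C=C\c1cccc(Br)c1)N1N=C(c2ccncc2)OC1c1c[nH]c2ccccc12` is not yet measured in this assay. It differs from compound 1 by 3-bromophenyl in place of 4-hydroxyphenyl on a double-bonded chain carbon bound to a double-bonded chain carbon. The step that bears on it is an at least 1.0-fold lower number from compound 1 to compound 2 (0.01 log units; that floor lies within the scatter), a change of aryl substitution at the same place that stayed within the scatter. No step beyond the scatter is therefore expected in this assay, and a value at or near the limit of compound 1 is the likely outcome. Compound 3 is expected to give 30 ug/mL in this assay, with a range of 15 ug/mL to 60 ug/mL. The step this estimate implies is expected to be a number no higher from compound 1 to compound 3 (the limit leaves the size open).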

Compound 3, concentration for 50% growth inhibition: > 30 ug/mL
Compound 3 was reported as a limit; the forecaster's own chance of this, stated with the estimate: 50%; the middle value lies on the limit itself.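

Compound 3 stands at a limit of the assay and not at a number in this assay, as compound 1 does, so the step between these two cannot be read. Among these compounds, the one readable new step is an at least 1.0-fold higher number from compound 2 to compound 3 (0.01 log units; that floor lies within the scatter), so moving from 2,4-dichlorophenyl to 3-bromophenyl at this place shows nothing beyond the scatter. With a second halogenated phenyl now tested on a double-bonded chain carbon, the readings at this place still crowd the top of the read-out: the limit of > 30 ug/mL in this assay, at which 2 of the 3 values shown sit.

On these data alone, whether any group at this place can give a number clearly lower than these stays open, for example an amine or a carboxylic acid on the phenyl ring, or a longer chain in place of the ethenyl link. As far as these compounds go, how far compound 1 and compound 3 actually lie from each other also stays open.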